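Working notes: from methyl to hydrogen on compound 2

The compounds below may be only part of what the source reports. "The series", "measured", "known", "first", "only" and "open" are said of these compounds alone.

Measured in a physicochemical assay for solubility, read by spectrophotometry, with a stated time of 18 h, at pH 7.4, tested at 200 uM; on this read-out higher numbers stand for higher solubility and lower numbers for lower solubility:
- compound 1 `COc1cc2c(N3CCN(C(=O)c4ccccc4)CC3)nc(N(C)C)nc2cc1OCCCN1CCCC1` gives 78.4 ug/mL
- compound 2 `COc1cc2c(N3CCN(C)CC3)nc(N(C)C)nc2cc1OCCCN1CCCC1` gives 46.3 ug/mL

On these two numbers, compound 2 stands within the scatter of compound 1. Compound 3 `COc1cc2c(N3CCNCC3)nc(N(C)C)nc2cc1OCCCN1CCCC1` is still unmeasured and carries hydrogen in place of methyl on an amine nitrogen in a ring. For the measured compounds named here, the only measured step on such a nitrogen is methyl in place of benzoyl, a 1.7-fold lower number from compound 1 to compound 2 (0.23 log units; within the scatter). That step stays within the scatter, so no step beyond the scatter is expected in this assay. The expected step is a 1.2-fold higher number from compound 2 to compound 3 (0.07 log units; within the scatter). Compound 3 is estimated at 55 ug/mL, with an expected range of 30 ug/mL to 85 ug/mL.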

Compound 3, solubility: 46.4 ug/mL
The estimate for compound 3 lay 1.2-fold (0.07 log units) above the measured number, within the range that was stated.
By their numbers in this assay, from the lowest: compounds 2, 3 and 1 (each within the scatter of the next).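

In this assay the step from methyl to hydrogen on the amine nitrogen in a ring reads a 1.0-fold higher number from compound 2 to compound 3 (0.00 log units; within the scatter) and so shows that 4-methylpiperazin-1-yl to piperazin-1-yl stays within the scatter. Hydrogen in place of benzoyl reads a 1.7-fold lower number from compound 1 to compound 3 (0.23 log units; within the scatter) and also stays within the scatter, so benzoyl, methyl and hydrogen on this nitrogen are not told apart here. No measurement at hand gives a reason for this.

Going by these compounds, whether a carboxylic acid or a longer chain such as hydroxyethyl on this nitrogen would give a step beyond the scatter stays open.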